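Aromatic substituent exchange and microsomal half-life

A few compounds are considered here, and "the series" means these few. Any claim that something is new, unique, unknown or untested is made for them only; others in the source may bear on it.

Measured compounds:
compound 1 `CNc1nc(NCCCN(C)C)c2sc(-c3ccc(-n4cccn4)cc3)cc2n1`: 1.66 h
compound 2 `CNc1nc(NCCCN(C)C)c2sc(-c3ccc(S(C)(=O)=O)cc3)cc2n1`: 1.92 h

In an ADME assay (liver) for metabolic stability, with Liver microsome (Homo sapiens) as the target, read by LC-MS, using microsomes, tested at 1 uM (on this read-out lower numbers stand for a shorter-lived compound and higher numbers for a longer-lived compound), compound 1 gives 1.66 h, and compound 2 gives 1.92 h. Among the compounds with values here, the only measured step, a 1.2-fold higher number from compound 1 to compound 2 (0.06 log units; within the scatter), replaces one group on the aromatic carbon with another and stays within the scatter, so compound 2 and compound 1 cannot be separated on these numbers; compound 2 is simply one of two measured compounds whose values sit within the scatter of each other.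

Compound 3 `CNc1nc(NCCCN(C)C)c2sc(-c3ccc(C(F)(F)F)cc3)cc2n1` differs from compound 2 by trifluoromethyl in place of methylsulfonyl on an aromatic carbon. Within the data shown here, no measured step involves trifluoromethyl, so the only guidance is the exchange at the same aromatic carbon, a 1.2-fold higher number from compound 1 to compound 2 (0.06 log units; within the scatter), which was within the scatter. On that basis no step beyond the scatter is expected in this assay for compound 3 in either direction, and the expected step of a 1.1-fold lower number from compound 2 to compound 3 (0.03 log units; within the scatter) is treated as flat. Compound 3 is therefore estimated at 1.8 h in this assay, with a range from 0.9 h to 3.6 h that mostly reflects the repeat scatter rather than a predicted change.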

Compound 3, half-life: 2.07 h
For compound 3 the middle estimate is 1.2-fold (0.06 log units) below the measured one, and the stated range covers the measured number.
By their numbers in this assay, from the lowest: compounds 1, 2 and 3 (each within the scatter of the next).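

In this assay, trifluoromethyl in place of methylsulfonyl gives a 1.1-fold higher number from compound 2 to compound 3 (0.03 log units; within the scatter) and trifluoromethyl in place of 1H-pyrazol-1-yl gives a 1.2-fold higher number from compound 1 to compound 3 (0.10 log units; within the scatter), so all three pairs among the measured compounds now lie within the scatter. This position, on an aromatic carbon para to a large group, has thus taken three different groups with no step beyond the scatter, and the exchange of methylsulfonyl, with 2 hydrogen-bond acceptors, for trifluoromethyl, with 0, at the same count of 4 heavy atoms, leaves the half-life unresolved from that of compound 2. No supporting information bears on why these three values sit so close.

As far as these compounds go, whether the half-life stays flat with groups of another kind at this position, such as a primary amine or a carboxylic acid, remains open. Also open, from the compounds shown here alone, is whether a change away from this position, such as a longer chain on the shared core, would give a step beyond the scatter.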